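Adding a chloro group to a nontoxic amide

The source may hold more compounds than are shown below. What is called first, only, known or untested is meant among the compounds shown, and "the series" means these compounds.

compound 1 `O=C(Nc1cccc(-n2cc(-c3ccncc3)c(-c3ccc(Cl)c(O)c3)n2)c1)Nc1cccc(C(F)(F)F)c1` (> 32500 nM)
compound 2 `COc1cc(-c2nn(-c3cccc(NC(=O)c4cccc(C(F)(F)F)c4)c3)cc2-c2ccncc2)ccc1Cl` (> 50000 nM)

Both results come from a functional assay on T47D cells (Homo sapiens) for inhibition, read by sulforhodamine B assay, with a stated time of 48 h (on this read-out lower numbers stand for higher toxicity in this test and higher numbers for lower toxicity in this test), and neither is an exact reading. Compound 2 stands at a limit of this assay (> 50000 nM), not at a measured number. Compound 1 likewise gives only a limit (> 32500 nM). Within the data shown here, no measured step between closely matched compounds is available as a guide.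

Compound 3 `COc1cc(-c2nn(-c3cccc(NC(=O)c4ccc(Cl)c(C(F)(F)F)c4)c3)cc2-c2ccncc2)ccc1Cl` keeps the structure of compound 2 except for one change on the outer ring, where 3-(trifluoromethyl)phenyl becomes 4-chloro-3-(trifluoromethyl)phenyl (chloro in place of hydrogen on an aromatic carbon). The new chloro group sits ortho to a trifluoromethyl group and para to a large group.

With so little to go on, the expectation in this assay is no shift beyond the usual scatter in either direction. That expectation starts from compound 2 (> 50000 nM). The expected change (a number no higher from compound 2 to compound 3 (the limit leaves the size open)) is therefore small, and another limit would be no surprise. Compound 3 is estimated at 50000 nM (expected range 20000 nM to 100000 nM).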

Compound 3, concentration lethal to 50% of the cells: > 32500 nM
Compound 3 was reported as a limit; the forecaster's own chance of this, stated with the estimate: 75%; the middle value does not contradict the limit.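

In this assay compound 3 gives > 32500 nM, which is a limit and not a number. Among these compounds, compound 2 also gives a limit, > 50000 nM, so no step from one to the other can be read. The compounds shown leave open whether the chloro group changes toxicity at all, and at what concentration any of them would be lethal to the cells.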